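This account rests on a few compounds, and the source may have more. Where it says the series, first, only, none or still open, it means among the compounds named here.

Compound 1 `Nc1nc([SeH])nc2ncccc12` and compound 2 `CCCCC[Se]c1nc(N)c2cccnc2n1` share one core. In a functional assay on HT-29 cells (Homo sapiens) for cytotoxicity, read by MTT assay, with a stated time of 72 h (a higher number here means a weaker inhibitor of growth, a lower number a stronger inhibitor of growth), compound 1 gives 36300 nM and compound 2 gives 5910 nM. The step of a 6.1-fold lower number from compound 1 to compound 2 (0.79 log units; beyond the scatter) came with pentyl in place of hydrogen on a selenium. Compound 3 `Nc1nc([SeH])nc2ccccc12` rests on a different core; the difference between the two cores is not broken down here. In this assay compound 3 gives 52200 nM, which stands within the scatter of the value of compound 1. Compound 4 `CCCCC[Se]c1nc(N)c2ccccc2n1` relates to compound 3 as compound 2 does to compound 1, through (pentyl in place of hydrogen on a selenium), the same change at the same kind of place. Because a 6.1-fold lower number from compound 1 to compound 2 (0.79 log units; beyond the scatter) was modest and the change is the same, a step of about a 5.8-fold lower number from compound 3 to compound 4 (0.76 log units; beyond the scatter) is expected in this assay. Compound 4 is therefore estimated at 9000 nM, with a likely range from 3000 nM to 27000 nM.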

Compound 4, concentration for 50% growth inhibition: 40300 nM
The estimate for compound 4 lay 4.5-fold (0.65 log units) below the measured number, outside the stated range (above it).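

In this assay, pentyl in place of hydrogen on a selenium gave a 1.3-fold lower number from compound 3 to compound 4 (0.11 log units; within the scatter), so on this core the change left the number within the scatter. The change therefore did not carry over in size from one core to the other: the same change on two cores in this assay, a 6.1-fold lower number (0.79 log units; beyond the scatter) from compound 1 to compound 2 and a 1.3-fold lower number (0.11 log units; within the scatter) from compound 3 to compound 4, 4.7-fold (0.68 log units) apart, beyond the scatter of two such steps. This shows that the size of the step cannot be assumed to transfer between these two cores, but it does not show which part of the difference between the cores matters, and one pair on each core gives no general rule for the series.

The compounds shown leave open whether a shorter chain such as methyl or a longer chain such as octyl on the selenium would show the same gap between the cores. They also leave open whether a benzyl group there would do so.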